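The compounds below may be only part of what the source reports. "The series", "measured", "known", "first", "only" and "open" are said of these compounds alone.

Measured compounds in a functional assay on MDA-MB-231 cells (Homo sapiens) for antiproliferative activity, read by CCK-8 assay, with a stated time of 72 h; a higher number here means a weaker inhibitor, a lower number a stronger inhibitor:
compound 1, `Cc1ccc(C(=O)Nc2cccc(-c3oc4cc(-c5ccc(F)cc5)ccc4c(=O)c3O)c2)cc1`, giving 4350 nM;
compound 2, `Cc1ccccc1C(=O)Nc1cccc(-c2oc3cc(-c4ccc(F)cc4)ccc3c(=O)c2O)c1`, giving 4910 nM.

Compound 2 has the highest of the two numbers in this assay, its nearest neighbour being compound 1, a difference that lies within the scatter. Within the data shown here, the step of a 1.1-fold higher number from compound 1 to compound 2 (0.05 log units; within the scatter) is the only measured step, and it concerns a methyl on the same phenyl ring. Among the measured compounds shown here, compound 3, `O=C(Nc1cccc(-c2oc3cc(-c4ccc(F)cc4)ccc3c(=O)c2O)c1)c1ccc(C(F)(F)F)cc1`, arises from compound 2 by 4-(trifluoromethyl)phenyl in place of 2-methylphenyl on a carbonyl carbon; no measured step bears on a trifluoromethyl group. Compound 3 is therefore expected near compound 2, with a step of a 1.1-fold lower number from compound 2 to compound 3 (0.04 log units; within the scatter). The estimate for compound 3 is 4500 nM, in the range 1800 nM to 11000 nM.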

Compound 3, half-maximal inhibitory concentration: 29400 nM
Estimate against measurement, compound 3: 6.5-fold (0.82 log units) below; the whole stated range lies below it.
By their numbers in this assay, from the lowest: compounds 1 and 2 (each within the scatter of the next); then compound 3.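

In this assay, among these compounds, the aryl group on the carbonyl carbon proves able to move the number, which the two methyl compounds did not show: their only step was a 1.1-fold higher number from compound 1 to compound 2 (0.05 log units; within the scatter). The new change gives a 6.0-fold higher number from compound 2 to compound 3 (0.78 log units; beyond the scatter), and trifluoromethyl in place of methyl on an aromatic carbon gives a 6.8-fold higher number from compound 1 to compound 3 (0.83 log units; beyond the scatter), both towards a weaker inhibitor. Nothing available explains this shift.

On these data alone, whether the shift belongs to trifluoromethyl alone stays open. As far as these compounds go, how a chlorine, a methoxy group or an amine on this ring would compare also remains unknown.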